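The source may hold more compounds than are shown below. What is called first, only, known or untested is meant among the compounds shown, and "the series" means these compounds.

Measured in an ADME assay on HeLa cells (Homo sapiens) for cytotoxicity, read by MTT assay; a lower number here means that less compound is tolerated, a higher number that more compound is tolerated:
Compound 1 `Cc1nc(-c2cccnc2)sc1-c1nnc(-c2ccc(Br)cc2)o1`: > 100 ug/mL
Compound 2 `Cc1nc(-c2cccnc2)sc1-c1nnc(-c2ccc([N+](=O)[O-])cc2)o1`: > 100 ug/mL
Compound 3 `COc1ccccc1-c1nnc(-c2sc(-c3cccnc3)nc2C)o1`: > 100 ug/mL

Each of these entries is a limit of the assay and not a number. Compound 3 therefore has no exact position, and it shares (the limit of > 100 ug/mL in this assay, at which 3 of the 3 values shown sit). Compound 4 `Cc1nc(-c2cccnc2)sc1-c1nnc(-c2ccc(Cl)cc2)o1` carries 4-chlorophenyl in place of 2-methoxyphenyl on an aromatic carbon. The closest measured change is a step that the two limits leave unreadable from compound 1 to compound 3, where 2-methoxyphenyl replaces 4-bromophenyl. The other is a step that the two limits leave unreadable from compound 1 to compound 2, where nitro replaces bromo. Neither gives a size, but neither produced a readable value. No change beyond the usual scatter is therefore expected in this assay. The expected change is a step that the limit leaves unreadable from compound 3 to compound 4. Compound 4 is estimated at 130 ug/mL, within an expected range of 60 ug/mL to 280 ug/mL.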

Compound 4, half-maximal cytotoxic concentration: > 100 ug/mL
Compound 4: no number, only a limit (the forecaster's own chance of this, stated with the estimate: 85%); the middle value lies beyond the limit too.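

Among these compounds, compounds 1, 2, 3 and 4 all give only a limit, not a number, so no step among them can be read in this assay: the limit of > 100 ug/mL in this assay, at which 4 of the 4 values shown sit. Where each compound's true value lies, and whether exchanging these groups changes it at all, stays open.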